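The compounds below may be only part of what the source reports. "The series", "measured", "known", "first", "only" and "open" are said of these compounds alone.

Among the measured compounds shown here, in a functional assay on HT-29 cells (Homo sapiens) for cytotoxicity, read by MTT assay, with a stated time of 72 h (a lower number here means a stronger inhibitor, a higher number a weaker inhibitor), compound 2 `Cc1cccc(Cl)c1NC(=O)CN1CCN(c2nnc(Cc3ccccc3)c3ccccc23)CC1` gives 53600 nM, the higher of the two numbers so far. Compound 1 `O=C(CN1CCN(c2nnc(Cc3ccncc3)c3ccccc23)CC1)Nc1cccc(Br)c1` gives 1350 nM, and the gap between the two compounds lies beyond the scatter. Compound 3 `O=C(CN1CCN(c2nnc(Cc3ccccc3)c3ccccc23)CC1)Nc1cccc(Br)c1` remains unmeasured. Its change from compound 2 is 3-bromophenyl in place of 2-chloro-6-methylphenyl on an amide-type nitrogen. Compound 1 also carries 3-bromophenyl on that nitrogen and gives 1350 nM, so a large move to a lower number, beyond the scatter, is expected in this assay. The estimated step is an 18-fold lower number from compound 2 to compound 3 (1.25 log units; beyond the scatter). Compound 3 is estimated at 3000 nM, with an expected range of 700 nM to 15000 nM.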

Compound 3, half-maximal inhibitory concentration: 13400 nM
The estimate for compound 3 lay 4.5-fold (0.65 log units) below the measured number; the range from low to high includes it.
By their numbers in this assay, from the lowest: compound 1; then compound 3; then compound 2.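

In this assay, 3-bromophenyl in place of 2-chloro-6-methylphenyl on the amide-type nitrogen gives a 4.0-fold lower number from compound 2 to compound 3 (0.60 log units; beyond the scatter), so this position moves the number while the rest of the structure stays fixed. Phenyl in place of pyridin-4-yl on the saturated chain carbon gives a 9.9-fold higher number from compound 1 to compound 3 (1.00 log units; beyond the scatter), so this second place also moves the number beyond the scatter. Nothing available gives a reason for either step. Still open, as far as these compounds go, is whether the first step follows the bromine or the loss of the chlorine and methyl, and how 3-methoxyphenyl on that nitrogen would read.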